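The source may report more compounds than this note shows. Statements on the series, on what has been measured and on what is new or still open speak of the compounds shown alone.

Compound 1 `N#Cc1ccc(C(c2ccc(C#N)cc2)n2cc(COc3ccccc3)nn2)cc1` and compound 2 `N#Cc1ccc(C(c2ccc(C#N)cc2)n2cc(COc3ccc(Cl)cc3)nn2)cc1` share a core that carries nitrile groups. In an assay on isolated protein for inhibition of Aromatase (Homo sapiens), read by fluorescence and colorimetric assay, with a stated time of 30 min (a higher number here means a weaker inhibitor, a lower number a stronger inhibitor), compound 1 gives 11000 nM, and compound 2 gives 16100 nM. The change between them is chloro in place of hydrogen on an aromatic carbon, and it made a 1.5-fold higher number from compound 1 to compound 2 (0.17 log units; within the scatter). Compound 3 `c1ccc(OCc2cn(C(c3ccccc3)c3ccccc3)nn2)cc1` has a core without those nitrile groups; the difference between the two cores is not broken down here. In this assay compound 3 gives 31300 nM. Compound 4 `Clc1ccc(OCc2cn(C(c3ccccc3)c3ccccc3)nn2)cc1` has not yet been measured; it differs from compound 3 by chloro in place of hydrogen on an aromatic carbon, the same change at the same kind of place. The step from compound 3 to compound 4 is expected to be a 1.4-fold higher number from compound 3 to compound 4 (0.16 log units; within the scatter), since the same change gave a 1.5-fold higher number from compound 1 to compound 2 (0.17 log units; within the scatter). Compound 4 is therefore expected to give about 45000 nM, somewhere between 20000 nM and 100000 nM.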

Compound 4, half-maximal inhibitory concentration: 13400 nM
The estimate for compound 4 lay 3.4-fold (0.53 log units) above the measured number; measured number below the stated range.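

On the core without nitrile groups, chloro in place of hydrogen gave a 2.3-fold lower number from compound 3 to compound 4 (0.37 log units; beyond the scatter), and in this assay this step does not match the one seen on the core that carries them: the same change on two cores in this assay, a 1.5-fold higher number (0.17 log units; within the scatter) from compound 1 to compound 2 and a 2.3-fold lower number (0.37 log units; beyond the scatter) from compound 3 to compound 4, 3.4-fold (0.53 log units) apart, beyond the scatter of two such steps

For these two pairs, then, the step measured on one core was a poor guide to the step on the other. This does not show why the two steps differ, and one pair on each core says nothing about how other cores would respond.

The compounds shown leave open whether bromo, methoxy or an amine at the same place would also give different steps on the two cores. They also leave open which part of the difference between the cores matters, including whether it is the nitrile groups.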